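Chloro for the remaining methyl: compound 4

The source may hold more compounds than are shown below. What is called first, only, known or untested is meant among the compounds shown, and "the series" means these compounds.

Measured so far in a functional assay on PC-3 cells (Homo sapiens) for cytotoxicity, read by WST assay, with a stated time of 72 h; on this read-out higher numbers stand for weaker inhibition and lower numbers for stronger inhibition:
compound 1 `Cc1ccc2c(c1C)NC(=O)C2(c1ccc(O)cc1)C1CCCCCC1`: > 1000 nM
compound 2 `Cc1c(F)ccc2c1NC(=O)C2(c1ccc(O)cc1)C1CCCCCC1`: 30 nM
compound 3 `Cc1c(Cl)ccc2c1NC(=O)C2(c1ccc(O)cc1)C1CCCCCC1`: 150 nM

Compound 1 stands at > 1000 nM, which is a limit of the assay and not a number. The other two compounds give numbers, and the measured steps from the limit are an at least 33-fold lower number from compound 1 to compound 2 (1.52 log units; beyond the scatter) and an at least 6.6-fold lower number from compound 1 to compound 3 (0.82 log units; beyond the scatter). Between the two halogens, the step is a 5.0-fold higher number from compound 2 to compound 3 (0.70 log units; beyond the scatter).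

Compound 4 `Cc1ccc2c(c1Cl)NC(=O)C2(c1ccc(O)cc1)C1CCCCCC1` is still unmeasured. It differs from compound 1 by chloro in place of methyl on an aromatic carbon, with chloro in place of methyl on an aromatic carbon, ortho to a fused ring and ortho to a methyl group.

Going by the values given here, the nearest precedent is an at least 6.6-fold lower number from compound 1 to compound 3 (0.82 log units; beyond the scatter), the same exchange of groups, but at the other methyl of compound 1. Among the compounds with values here, compound 4 keeps that methyl, and no measured compound shows a change at the one replaced here, so the precedent carries over only loosely. A step to a lower number in this assay is expected, probably not as large as the precedent, and the expected step is an at least 2.5-fold lower number from compound 1 to compound 4 (0.39 log units; beyond the scatter). Compound 4 is expected at 400 nM, with an estimated range of 80 nM to 2000 nM.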

Compound 4, half-maximal inhibitory concentration: 17 nM
Compound 4: the middle estimate sits 24-fold (1.37 log units) above what was measured; measured number below the stated range.
By their numbers in this assay, from the lowest: compounds 4 and 2 (each within the scatter of the next); then compound 3. At a limit, above all of these: compound 1.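

The position ortho to a fused ring and ortho to a methyl group now has a measured change of its own: in this assay, chloro in place of methyl there gives an at least 58-fold lower number from compound 1 to compound 4 (1.76 log units; beyond the scatter) in a step read as large. Compounds 2 and 3 change only the other methyl of compound 1, so chloro for methyl now lowers the number at both methyl positions, the other case being an at least 6.6-fold lower number from compound 1 to compound 3 (0.82 log units; beyond the scatter) in the same exchange. Compound 1 gives a limit and not a number, so neither step has a known full size and the two cannot be ranked: the limit of > 1000 nM in this assay, at which 1 of the 4 values shown sits.

The compounds shown leave open how fluoro, methoxy or an amine would behave at this position. They also leave open whether the result at this position depends on the methyl group kept in compound 4.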